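The compounds below may be only part of what the source reports. "The series", "measured", "known", "first", "only" and "open" are said of these compounds alone.

In a functional assay on Shh Light II cells (Mus musculus) for inhibition, read by a luciferase reporter (on this read-out higher numbers stand for weaker inhibition and lower numbers for stronger inhibition), compound 1 `O=C(Nc1cccc2cccnc12)N1CCC(c2nc(-c3ccc4ccccc4n3)no2)CC1` gives 1400 nM. Compound 2 `O=C(OCc1ccccc1)N1CCC(c2nc(-c3ccc4ccccc4n3)no2)CC1` reaches only a limit of the assay, > 2500 nM. Compound 3 `O=C(Nc1cccnc1Cl)N1CCC(c2nc(-c3ccc4ccccc4n3)no2)CC1` carries (2-chloropyridin-3-yl)amino in place of benzyloxy on a carbonyl carbon. Going by the values given here, the only measured step bearing on this change is an at least 1.7-fold higher number from compound 1 to compound 2 (0.25 log units; that floor lies within the scatter), which went from an amino group to benzyloxy at that same place. A modest move towards a lower number in this assay is therefore expected, though that one step fixes its size poorly. The expected step is an at least 1.3-fold lower number from compound 2 to compound 3 (0.14 log units; that floor lies within the scatter). For compound 3 the estimated value is 1800 nM, with an expected range of 600 nM to 5000 nM.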

Compound 3, half-maximal inhibitory concentration: 1600 nM
Compound 3: the middle estimate sits 1.1-fold (0.05 log units) above what was measured; the range from low to high includes it.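

Putting (2-chloropyridin-3-yl)amino on the carbonyl carbon gives an at least 1.5-fold lower number from compound 2 to compound 3 (0.19 log units; that floor lies within the scatter) in this assay, so this comparison with benzyloxy yields only a floor: the limit of > 2500 nM in this assay, at which 1 of the 3 values shown sits. With 2-chloropyridin-3-yl in place of quinolin-8-yl on the amide-type nitrogen, the change is a 1.1-fold higher number from compound 1 to compound 3 (0.06 log units; within the scatter), so these two groups cannot be told apart in this read-out. From the compounds shown here alone, it remains open whether a plain phenyl or a cyclohexyl on that nitrogen would read the same, and whether a methyl in place of the amide hydrogen would shift the value.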